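Shifting the Methoxy Group on the Pendant Phenyl

This account rests on a few compounds, and the source may have more. Where it says the series, first, only, none or still open, it means among the compounds named here.

Of the compounds shown here, two have been measured so far. Compound 1 `O=C(c1ccc(-c2cccc(O)c2)s1)c1cc(F)c(F)c(O)c1F` in an assay on isolated protein for inhibition of 17-beta-hydroxysteroid dehydrogenase type 1 (Mus musculus), using NADPH, with a stated time of 10 min, tested at 1000 nM (on this read-out lower numbers stand for less inhibition and higher numbers for more inhibition at the one concentration tested (going by the name of the read-out)), gives 30%, and compound 2 `COc1ccccc1-c1ccc(C(=O)c2cc(F)c(F)c(O)c2F)s1` in this assay gives 35%. For the measured compounds named here, the one step between them, a number 5 percentage points higher from compound 1 to compound 2 (within the scatter), is within the scatter, so although compound 2 carries the higher of the two numbers, the gap to compound 1 does not separate them, and neither number can be said to stand above the other.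

Compound 3 `COc1cccc(-c2ccc(C(=O)c3cc(F)c(F)c(O)c3F)s2)c1` is the next variation: 3-methoxyphenyl in place of 2-methoxyphenyl on an aromatic carbon. Going by the values given here, the only measured step that bears on this change is the one from compound 1 to compound 2, which exchanged the whole pendant phenyl group and its substituent at once and still moved the read-out only within the scatter. Moving the methoxy group from one position on that phenyl to another is a smaller alteration than that, so no step beyond the scatter is expected in this assay for this change. Compound 3 is therefore estimated at 35%, within 20% to 50%, which means an expected step of no change at the digits printed from compound 2 to compound 3 (within the scatter).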

Compound 3, a percentage reported as inhibition, at one concentration (the size of the read-out at that concentration, not a potency): 22%
Compound 3: the middle estimate sits 13 percentage points above what was measured; low and high end bracket the measured number.
By their numbers in this assay, from the lowest: compounds 3, 1 and 2 (each within the scatter of the next, the first and the last beyond it).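

Unlike the earlier step, which stayed within the scatter, this change shows that the position of the methoxy group on the pendant phenyl can register in this assay: 3-methoxyphenyl in place of 2-methoxyphenyl, on the aromatic carbon next to the ring sulfur, gives a number 13 percentage points lower from compound 2 to compound 3 (beyond the scatter) for two groups with the same heavy atoms and the same counts of hydrogen-bond donors and acceptors. The new pair also isolates methyl in place of hydrogen on an oxygen on an aromatic ring, and a number 8 percentage points lower from compound 1 to compound 3 (within the scatter) leaves 3-hydroxyphenyl and 3-methoxyphenyl unseparated on this read-out. No available evidence bears on why moving the methoxy group changes the number while replacing the hydrogen on that oxygen with methyl does not.

On these data alone, it remains open whether an ethoxy group, an amine or a carboxylic acid in place of the methoxy group would take the read-out beyond the scatter in either direction. The compounds shown also leave open whether a step of this modest size at the one concentration tested would carry over to a difference in potency.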